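The compounds below may be only part of what the source reports. "The series", "measured", "known", "first", "only" and "open" are said of these compounds alone.

Compound 1 `COc1ccc(CS(=O)(=O)/C=C/c2ccccc2OC)cc1` is the simplest member of this small set, and in a functional assay on BT-20 cells (Homo sapiens) for antiproliferative activity, read by trypan blue exclusion (on this read-out lower numbers stand for stronger inhibition and higher numbers for weaker inhibition), compound 1 gives 5000 nM. Among the measured compounds shown here, compound 2 `COc1ccc(CS(=O)(=O)/C=C/c2c(OC)cccc2OC)cc1` differs from it by one change, (methoxy in place of hydrogen on an aromatic carbon), and in this assay compound 2 gives 400 nM; the step of a 13-fold lower number from compound 1 to compound 2 (1.10 log units; beyond the scatter) is the only counted step among the measured compounds. Compound 3 `COc1ccc(CS(=O)(=O)/C=C/c2cc(OC)cc(OC)c2)cc1` carries its methoxy groups on a different pattern of the same ring; how the core of compound 3 differs from the core of compound 1 is not broken down here. For compound 3 the result in this assay is only a limit, > 20000 nM, the mark described by the limit of > 20000 nM in this assay, at which 1 of the 3 values shown sits.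

Compound 4 `COc1ccc(CS(=O)(=O)/C=C/c2cc(OC)c(OC)c(OC)c2)cc1`, not yet measured, arises from compound 3 by methoxy in place of hydrogen on an aromatic carbon. For the measured compounds named here, this is the same kind of change as the one from compound 1 to compound 2, but not the same: there the entering methoxy sat ortho to a large group and meta to a methoxy group, whereas here it sits ortho to two methoxy groups and para to a large group. Since compound 3 yields only a limit, the starting point of the step is itself uncertain. Taking the earlier step as a rough guide, compound 4 is expected to improve on compound 3 by about an at least 5.0-fold lower number from compound 3 to compound 4 (0.69 log units; beyond the scatter), and in this assay compound 4 is estimated at 4000 nM, somewhere between 300 nM and 40000 nM.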

Compound 4, half-maximal inhibitory concentration: > 20000 nM
Compound 4 gave a limit, no number; the forecaster's own chance of this, stated with the estimate: 35%; middle value at least 5.0-fold (0.69 log units) from the limit.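

Compound 3 and compound 4 both end at a limit in this assay, so no size can be read for the step between them, and the comparison stays unreadable: the limit of > 20000 nM in this assay, at which 2 of the 4 values shown sit.

The compounds shown leave open whether a methoxy ortho to two methoxy groups and para to a large group changes the result in this assay at all.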